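This account rests on a few compounds, and the source may have more. Where it says the series, first, only, none or still open, it means among the compounds named here.

Compound 1 `CCCN(CCC(F)(F)F)Cc1c(C(F)(F)F)nc2n(-c3c(C)cc(C)cc3C)c(Cl)cn12` gives 12 nM in an assay on cells for displacement of a labelled ligand from corticotropin-releasing factor receptor 1 (Homo sapiens), with a stated time of 100 min (on this read-out lower numbers stand for stronger inhibition and higher numbers for weaker inhibition), level with compound 2 `Cc1cc(C)c(-n2c(Cl)cn3c(CN(CCC(F)(F)F)Cc4ccc(Cl)cc4)c(C(F)(F)F)nc23)c(C)c1` at 12 nM, the two together the lowest of the three numbers measured. Compound 3 `CCCN(Cc1ccc([N+](=O)[O-])cc1)Cc1c(C(F)(F)F)nc2n(-c3c(C)cc(C)cc3C)c(Cl)cn12` gives 150 nM, and a 13-fold higher number from compound 1 to compound 3 (1.10 log units; beyond the scatter), whereas no change at the digits printed from compound 1 to compound 2 (within the scatter).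

Compound 4 `CCN(Cc1ccccc1)Cc1c(C(F)(F)F)nc2n(-c3c(C)cc(C)cc3C)c(Cl)cn12` differs from compound 1 as follows: benzyl(ethyl)amino in place of propyl(3,3,3-trifluoropropyl)amino on a saturated chain carbon bound to an aromatic carbon

Both measured steps bear on this change. An aryl in place of ethyl left this assay unchanged, while an aryl in place of the fluorinated arm cost a large step. Compound 4 alters both arms at once, so a moderate weakening is expected, a 3.3-fold higher number from compound 1 to compound 4 (0.52 log units; beyond the scatter), with the estimate for compound 4 at 40 nM and a range from 12 nM to 150 nM.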

Compound 4, inhibition constant: 350 nM
The estimate for compound 4 lay 8.8-fold (0.94 log units) below the measured number; the whole stated range lies below it.
By their numbers in this assay, from the lowest: compounds 1 and 2 (each within the scatter of the next); then compound 3; then compound 4.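

With an equal heavy-atom count on both sides, benzyl(ethyl)amino in place of propyl(3,3,3-trifluoropropyl)amino gives a 29-fold higher number from compound 1 to compound 4 (1.46 log units; beyond the scatter) in this assay, so this position does not tolerate every amine of that size. Among the four compounds, the two that keep the 3,3,3-trifluoropropyl arm, compounds 1 and 2, hold the lowest numbers, and compounds 3 and 4, which lack it, stand higher, with none going against this. No measurement shown accounts for the step.

Still open, as far as these compounds go, is how much of the step belongs to each arm, since both change at once. A butyl arm in place of the 3,3,3-trifluoropropyl arm, with propyl kept, would separate the fluorines from the chain.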